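Pyridin-4-yl Replacing 3-Fluorophenyl in a Sulfonylurea Chalcone Series

The source may hold more compounds than are shown below. What is called first, only, known or untested is meant among the compounds shown, and "the series" means these compounds.

Compound 1 `Cc1ccc(S(=O)(=O)NC(=O)Nc2ccccc2C(=O)/C=C/c2ccccc2)cc1` in an ADME assay on the whole organism for cytotoxicity, with Artemia salina as the target, with a stated time of 24 h (a higher number here means that more compound is needed for the effect, a lower number that less compound is needed), gives 25 ug/mL.
Compound 2 `Cc1ccc(S(=O)(=O)NC(=O)Nc2ccccc2C(=O)/C=C/c2ccccc2O)cc1` gives 32.3 ug/mL.
Compound 3 `Cc1ccc(S(=O)(=O)NC(=O)Nc2ccccc2C(=O)/C=C/c2cccc(F)c2)cc1` gives 4.13 ug/mL.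

Compound 3 gives the lowest of the three numbers; the nearest is compound 1 at a 6.1-fold lower number from compound 1 to compound 3 (0.78 log units; beyond the scatter), the furthest compound 2 at a 7.8-fold lower number from compound 2 to compound 3 (0.89 log units; beyond the scatter). Compound 4 `Cc1ccc(S(=O)(=O)NC(=O)Nc2ccccc2C(=O)/C=C/c2ccncc2)cc1` differs from compound 3 as follows: pyridin-4-yl in place of 3-fluorophenyl on a double-bonded chain carbon bound to a double-bonded chain carbon. For the measured compounds named here, no measured step shows the effect of a pyridin-4-yl here. The closest guides are the steps of a 6.1-fold lower number from compound 1 to compound 3 (0.78 log units; beyond the scatter) and a 1.3-fold higher number from compound 1 to compound 2 (0.11 log units; within the scatter), which show that one ring substitution moved the number modestly while another left it within the scatter. Because the step to compound 3, a 6.1-fold lower number from compound 1 to compound 3 (0.78 log units; beyond the scatter), rests on the fluoro that now leaves, compound 4 is expected to move back toward compound 1, a 2.9-fold higher number from compound 3 to compound 4 (0.46 log units; beyond the scatter). The estimate for compound 4 is 12 ug/mL, ranging from 4 ug/mL to 40 ug/mL.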

Compound 4, concentration for half-maximal effect: 16.8 ug/mL
Compound 4: middle estimate off by 1.4-fold (0.15 log units), on the low side; the range from low to high includes it.
By their numbers in this assay, from the lowest: compound 3; then compounds 4, 1 and 2 (each within the scatter of the next).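

In this assay, pyridin-4-yl on this double-bonded chain carbon does not keep the low number seen with 3-fluorophenyl (a 4.1-fold higher number from compound 3 to compound 4 (0.61 log units; beyond the scatter)). Set against the phenyl and 2-hydroxyphenyl rings, pyridin-4-yl lies within the scatter (a 1.5-fold lower number from compound 1 to compound 4 (0.17 log units; within the scatter); a 1.9-fold lower number from compound 2 to compound 4 (0.28 log units; within the scatter)), so of these four rings only 3-fluorophenyl stands apart. No evidence at hand accounts for this result.

The compounds shown leave open whether the low number is particular to fluoro or would also appear with a chlorophenyl ring, and what a carboxylic acid or an amine on this ring would do.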